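The compounds below may be only part of what the source reports. "The series", "measured", "known", "first", "only" and "open" are said of these compounds alone.

Measured in a functional assay on HCT-116 cells (Homo sapiens) for inhibition, read by sulforhodamine B assay, with a stated time of 48 h, tested at 50 uM; a lower number here means less inhibition of growth, a higher number more inhibition of growth at the concentration tested:
- compound 1 `COc1cc(/C=C/C(=O)/C=C/c2cccs2)ccc1OCc1cn(CCOc2cc(=O)oc3ccccc23)nn1`: 71%
- compound 2 `COc1cc(/C=C/C(=O)/C=C/c2cccs2)ccc1OCc1cn(CCCCOc2cc(=O)oc3ccccc23)nn1`: 41%
- compound 3 `COc1cc(/C=C/C(=O)/C=C/c2ccco2)ccc1OCc1cn(CCCCCOc2cc(=O)oc3ccccc23)nn1`: 37%

Among these three, compound 1 stands highest. Compound 1 at 71% lies beyond the usual scatter from both of the others, with compound 2 at 41% and compound 3 at 37%.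

The next compound to be tested in this assay is compound 4 `COc1ccc(/C=C/C(=O)/C=C/c2ccc(OCc3cn(CCOc4cc(=O)oc5ccccc45)nn3)c(OC)c2)cc1`, which departs from compound 1 at a single place: 4-methoxyphenyl in place of thiophen-2-yl on a double-bonded chain carbon bound to a double-bonded chain carbon. In words, 4-methoxyphenyl takes the place of thiophen-2-yl on a double-bonded chain carbon bound to a double-bonded chain carbon, while the rest of compound 1 stays as it is.

Within the data shown here, no pair of measured compounds isolates this exchange, so the data give no direct size for it. The expectation therefore starts from compound 1 at 71%, the top of the measured values, and allows for a moderate fall rather than a rise. The step expected is a number 11 percentage points lower from compound 1 to compound 4 (beyond the scatter), an estimate that remains uncertain. For compound 4 the estimated value is 60%, with an expected range from 38% to 78%.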

Compound 4, percent growth inhibition at one concentration: 71%
Estimate against measurement, compound 4: 11 percentage points below; the range from low to high includes it.
By their numbers in this assay, from the lowest: compounds 3 and 2 (each within the scatter of the next); then compounds 1 and 4 (each within the scatter of the next).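

Among these compounds, putting 4-methoxyphenyl in place of thiophen-2-yl on a double-bonded chain carbon bound to a double-bonded chain carbon gives no change at the digits printed from compound 1 to compound 4 (within the scatter) in this assay, and this is the first step in the set that can be read at a single place. It shows that, at the one concentration tested, this position takes a six-membered aromatic ring of carbon only, with 8 heavy atoms in the group, as well as the five-membered aromatic ring with 1 hetero atom and 5 heavy atoms, so the sulfur of thiophen-2-yl is not needed for the growth inhibition seen with compound 1. Nothing available explains why the two groups read alike.

Going by these compounds, whether 4-methoxyphenyl would read the same way on the longer chain of compound 2 remains open. Also open, on these data alone, is what this position would give with a 4-(dimethylamino)phenyl group, an amine, or a 4-carboxyphenyl group, a carboxylic acid, in place of 4-methoxyphenyl on the core of compound 1.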